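One Fluorine Fewer on the Benzyl Arm

The compounds below may be only part of what the source reports. "The series", "measured", "known", "first", "only" and "open" are said of these compounds alone.

Compound 1 `CCOC(=O)CN(Cc1cc(F)cc(F)c1)c1ccc2c(c1)OC(C)(COc1ccc(C#N)cc1)CN2C` — 54000 nM
Compound 2 `CCOC(=O)C(=O)N(Cc1cc(F)cc(F)c1)c1ccc2c(c1)OC(C)(CO)CN2C` — 45000 nM
Compound 3 `CCOC(=O)CN(Cc1cccc(F)c1)c1ccc2c(c1)N(C)CC(C)(COc1ccc(C#N)cc1)O2` — > 100000 nM

Of the compounds shown here, three built on the shared core have been tested in a functional assay on MCF7 cells (Homo sapiens) for antiproliferative activity, read by cell counting, with a stated time of 4 days; on this read-out higher numbers stand for weaker inhibition and lower numbers for stronger inhibition. Compound 1 gives 54000 nM, and compound 2 gives 45000 nM; the two numbers lie within the scatter of each other, so neither can be called the more active. Compound 3 reaches only the limit of this assay, > 100000 nM, and no number is known for it beyond that: it is one of the values described by the limit of > 100000 nM in this assay, at which 1 of the 3 values shown sits. Across the three, then, the numbers are weak throughout and the spread between them is small.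

Compound 4 `CCOC(=O)CN(Cc1ccc(F)cc1)c1ccc2c(c1)OC(C)(COc1ccc(C#N)cc1)CN2C` has not yet been measured. It differs from compound 1 in one place: 4-fluorophenyl in place of 3,5-difluorophenyl on a saturated chain carbon bound to a nitrogen on an aromatic ring. Within the data shown here, since no pair of measured compounds differs in this single place, the size of the step has to be guessed. Given that compound 1 sits at 54000 nM and the only other number lies within the scatter, the expected step from compound 1 to compound 4 is a 1.1-fold higher number from compound 1 to compound 4 (0.05 log units; within the scatter), no larger than the scatter in either direction. Compound 4 is therefore estimated at 60000 nM, with a range from 25000 nM to 150000 nM, and a real chance that this assay reports only a limit for it.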

Compound 4, half-maximal inhibitory concentration: > 100000 nM
Compound 4: only a limit was reported (the forecaster's own chance of this, stated with the estimate: 35%); middle value at least 1.6-fold (0.22 log units) from the limit.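

In this assay compound 4 is reported only as a limit of the assay, > 100000 nM, and not as a number. This gives the first step read at this position on the benzyl arm, an at least 1.8-fold higher number from compound 1 to compound 4 (0.26 log units; that floor lies within the scatter), and as the floor of that step is all that is known, it does not establish a loss of activity; it shows only that 4-fluorobenzyl in place of 3,5-difluorobenzyl brings no gain on this read-out. With one more compound out of numerical range, fewer values remain that can be set against each other: the limit of > 100000 nM in this assay, at which 2 of the 4 values shown sit.

As far as these compounds go, how far the true value of compound 4 lies past the limit stays unknown, so the full size of the step cannot be read. Also open, from the compounds shown here alone, is whether another group at this place, such as an unsubstituted benzyl, a pyridylmethyl or a longer chain ending in an amine, would give a number clearly lower than that of compound 1, since every value shown remains weak.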